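Anilino swap on the shared core: methoxy out, chloro in

The source may report more compounds than this note shows. Statements on the series, on what has been measured and on what is new or still open speak of the compounds shown alone.

For the measured compounds named here, compound 1 `C#CCSc1nc(Nc2ccc(OC)cc2)c(C#N)c(-c2ccccc2)n1` carries the only numerical value in the set: in a functional assay on MGC-803 cells (Homo sapiens) for inhibition, read by MTT assay, with a stated time of 72 h (a higher number here means a weaker inhibitor, a lower number a stronger inhibitor), compound 1 gives 28400 nM. Compound 2 `C#CCSc1nc(Nc2cccc(C(F)(F)F)c2)c(C#N)c(-c2ccccc2)n1` sits at a limit of this assay, > 128000 nM, so it gives no number to compare. Compound 3 `C#CCSc1nc(Nc2ccccc2Cl)c(C#N)c(-c2ccccc2)n1` differs from compound 1 by one change: 2-chlorophenyl in place of 4-methoxyphenyl on a nitrogen on an aromatic ring. Going by the values given here, no measured step in this assay informs that change, so its size is a guess. A modest weakening is expected, a 2.1-fold higher number from compound 1 to compound 3 (0.32 log units; beyond the scatter), with some chance that compound 3 also reports only a limit. Compound 3 is estimated at 60000 nM, within 20000 nM to 200000 nM.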

Compound 3, half-maximal inhibitory concentration: 52800 nM
Estimate against measurement, compound 3: 1.1-fold (0.06 log units) above; the range from low to high includes it.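

The swap gives a 1.9-fold higher number from compound 1 to compound 3 (0.27 log units; within the scatter) in this assay, so 2-chlorophenyl and 4-methoxyphenyl on a nitrogen on an aromatic ring are not told apart in this pair. For the compounds shown here, this is the first readable step, and compound 3 still reports a number. Compound 2 stands at a limit, so steps to it cannot be read: the limit of > 128000 nM in this assay, at which 1 of the 3 values shown sits.

Still open, from the compounds shown here alone, is what an unsubstituted phenyl, or an aminophenyl or carboxyphenyl group, would give on that nitrogen. Also open, going by these compounds, is whether any group there moves the value beyond the scatter.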